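Amide Nitrogen Substitution on a Shared Core: Compound 3

The source may report more compounds than this note shows. Statements on the series, on what has been measured and on what is new or still open speak of the compounds shown alone.

Compound 1 `CCCCc1oc2ccccc2c1C(=O)c1ccc(OCC(N)=O)cc1` carries hydrogen on an amide-type nitrogen. In a functional assay on MCF7 cells (Homo sapiens) for antiproliferative activity, read by MTT assay, with a stated time of 24 h (a higher number here means a weaker inhibitor, a lower number a stronger inhibitor), compound 1 gives only a limit, > 50000 nM, as the limit of > 50000 nM in this assay, at which 1 of the 2 values shown sits, marks. Compound 2 `CCCCc1oc2ccccc2c1C(=O)c1ccc(OCC(=O)Nc2cccc(OC)c2)cc1` carries 3-methoxyphenyl on the amide-type nitrogen; in this assay compound 2 gives 38500 nM, a step of an at least 1.2-fold lower number from compound 1 to compound 2 (0.11 log units; that floor lies within the scatter). Compound 3 `CCCCc1oc2ccccc2c1C(=O)c1ccc(OCC(=O)N[C@@H](C)c2ccccc2)cc1` differs from compound 1 by 1-phenylethyl in place of hydrogen on an amide-type nitrogen. Going by the values given here, the one measured step that bears on it was at most a small lowering, so a similarly small step is expected in this assay. Compound 3 is therefore estimated at 35000 nM, within 15000 nM to 80000 nM, a step of an at least 1.4-fold lower number from compound 1 to compound 3 (0.15 log units; that floor lies within the scatter).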

Compound 3, half-maximal inhibitory concentration: 17900 nM
Beside the measured number, compound 3's estimate is 2.0-fold (0.29 log units) above it; the range from low to high includes it.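

In this assay, going by these compounds alone, 1-phenylethyl on the amide-type nitrogen gives the first change here that lies beyond the scatter (an at least 2.7-fold lower number from compound 1 to compound 3 (0.44 log units; beyond the scatter)). Replacing 3-methoxyphenyl with 1-phenylethyl also moves the number beyond the scatter (a 2.2-fold lower number from compound 2 to compound 3 (0.33 log units; beyond the scatter)), so at this position the identity of the entering group matters, not only the loss of the amide hydrogen. The step from hydrogen can be read only as a floor, because compound 1 stands at a limit: the limit of > 50000 nM in this assay, at which 1 of the 3 values shown sits.

The compounds shown leave open whether a benzyl group, without the methyl carbon of 1-phenylethyl, would give a similar number. They also leave open how the opposite configuration at the stereocentre would compare with compound 3.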